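Working notes: from compound 2 to compound 4

The source may report more compounds than this note shows. Statements on the series, on what has been measured and on what is new or still open speak of the compounds shown alone.

Values in an ADME assay on microsomes from liver (Homo sapiens) for metabolic stability, using NADPH, with a stated time of 10 min (a lower number here means that less of the compound is left, a higher number that more of the compound is left), so far
Compound 1 `NCCCCN(C[C@H]1Cc2ncccc2CN1)[C@H]1CCCc2cccnc21` gives 100%
Compound 2 `CN(C[C@H]1Cc2ncccc2CN1)[C@H]1CCCc2cccnc21` gives 95%
Compound 3 `CN(C[C@@H]1Cc2ncccc2CN1)[C@H]1CCCc2cccnc21` gives 100%
Compound 4 `NC/C=C\CN(C[C@H]1Cc2ncccc2CN1)[C@H]1CCCc2cccnc21` is not yet measured

Compound 2 at 95% stands within the scatter of both other measured compounds. The change now in view is 3-aminoprop-1-en-1-yl in place of hydrogen on a saturated chain carbon bound to an amine nitrogen or in words 3-aminoprop-1-en-1-yl in place of hydrogen on a saturated chain carbon bound to an amine nitrogen. Among the compounds with values here, two measured steps bear on it. The closer one is a number 5 percentage points lower from compound 1 to compound 2 (within the scatter) and it concerns the same kind of place, where compound 1 carries 3-aminopropyl. The other is a number 5 percentage points higher from compound 2 to compound 3 (within the scatter) and given the fact that compounds 2 and 3 differ only in the configuration as drawn it bears only weakly on the new chain. Neither step leaves the scatter, so no step beyond the scatter is expected in this assay here. The expected change is a number 2 percentage points lower from compound 2 to compound 4 (within the scatter) and it is estimated to stay within that scatter. For compound 4 the estimated value is 93% with an expected range of 80% to 100% in this read-out.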

Compound 4, percent of the compound remaining: 85%
Compound 4: the middle estimate sits 8 percentage points above what was measured; the measured number falls inside the stated range.
By their numbers in this assay, from the lowest: compounds 4, 2, 1 and 3 (each within the scatter of the next, the first and the last beyond it).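

In this assay, 3-aminoprop-1-en-1-yl in place of 3-aminopropyl on a saturated chain carbon bound to an amine nitrogen gives a number 15 percentage points lower from compound 1 to compound 4 (beyond the scatter) and so shows that this place can respond to the form of the chain. Against hydrogen at the same place, the same chain gives a number 10 percentage points lower from compound 2 to compound 4 (within the scatter) and does not leave the scatter, so only the comparison between the two chains separates compound 4 from another compound at this place. Nothing measured for these compounds accounts for the step.

Open, as far as these compounds go, is whether a longer chain, or a hydroxyl in place of the amine of the chain, would stay within the scatter of compound 2 at this place. Also open, from the compounds shown here alone, is how 3-aminoprop-1-en-1-yl behaves on the configuration drawn in compound 3.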